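Chloro for nitro on the triazole aryl of compound 2

The compounds below may be only part of what the source reports. "The series", "measured", "known", "first", "only" and "open" are said of these compounds alone.

Compound 2 `N#CC1=C(N)Oc2c(N)cc3nc4ccccc4nc3c2C12C(=O)N(Cc1cnnn1-c1ccc([N+](=O)[O-])cc1[N+](=O)[O-])c1ccccc12` sits at the limit of a functional assay on A549 cells (Homo sapiens) for antiproliferative activity, read by MTT assay, with a stated time of 48 h; a lower number here means a stronger inhibitor, a higher number a weaker inhibitor: compound 2 gives > 50000 nM, which is a limit of the assay rather than a number (the limit of > 50000 nM in this assay, at which 1 of the 2 values shown sits). Among the measured compounds shown here, compound 1 `CCc1ccccc1-n1nncc1CN1C(=O)C2(C(C#N)=C(N)Oc3c(N)cc4nc5ccccc5nc4c32)c2ccccc21` gives 24600 nM in this assay, so the step of an at least 2.0-fold higher number from compound 1 to compound 2 (0.30 log units; that floor lies within the scatter) is the only measured step in the set. Compound 3 `N#CC1=C(N)Oc2c(N)cc3nc4ccccc4nc3c2C12C(=O)N(Cc1cnnn1-c1ccc(Cl)cc1[N+](=O)[O-])c1ccccc12` is not yet measured; compared with compound 2 it carries chloro in place of nitro on an aromatic carbon. For the measured compounds named here, no measured step swaps a nitro for a chloro. The one that bears on it at all, an at least 2.0-fold higher number from compound 1 to compound 2 (0.30 log units; that floor lies within the scatter), changes the group on the aromatic nitrogen and shows that altering it can carry the number to the limit. That step gives no direction for the present change, so a step of an at least 1.2-fold lower number from compound 2 to compound 3 (0.09 log units; that floor lies within the scatter) is expected, with a fair chance that only a limit is reported again. Compound 3 is estimated at 40000 nM, with a range from 15000 nM to 100000 nM.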

Compound 3, half-maximal inhibitory concentration: > 50000 nM
Compound 3 ended at the assay's limit (the forecaster's own chance of this, stated with the estimate: 50%); at least 1.2-fold (0.09 log units) between middle value and limit.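

In this assay compound 3 gives > 50000 nM as a limit of the assay, not a number, so chloro in place of one nitro does not bring the reading off the limit that compound 2 also holds, and the step between these two limits cannot be read. Against 2-ethylphenyl the only readable comparison is an at least 2.0-fold higher number from compound 1 to compound 3 (0.30 log units; that floor lies within the scatter) and so shows no separation beyond the scatter. The 4-chloro-2-nitrophenyl and 2,4-dinitrophenyl groups therefore give the same kind of reading, a limit rather than a number: the limit of > 50000 nM in this assay, at which 2 of the 3 values shown sit.

On these data alone, whether the remaining nitro holds compound 3 at the limit stays open. So does the reading of an amine or a methoxy group in place of the chloro, or of the ethyl group of compound 1 on a ring that also carries chloro.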